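Working notes: hydroxy to methoxy on the chloro core

The source may hold more compounds than are shown below. What is called first, only, known or untested is meant among the compounds shown, and "the series" means these compounds.

Compound 1 `O=C(/C=C\Nc1ccc(O)cc1)c1cn(-c2ccccc2)nc1-c1ccccc1` carries a 4-hydroxyphenyl group on the shared core; in a functional assay on A549 cells (Homo sapiens) for antiproliferative activity, read by MTT assay, with a stated time of 48 h (on this read-out lower numbers stand for stronger inhibition and higher numbers for weaker inhibition), compound 1 gives 3210 nM. Compound 2 `COc1ccc(N/C=C\C(=O)c2cn(-c3ccccc3)nc2-c2ccccc2)cc1` differs from it by methyl in place of hydrogen on an oxygen on an aromatic ring, and in this assay compound 2 gives 3250 nM; the step is a 1.0-fold higher number from compound 1 to compound 2 (0.01 log units; within the scatter). Compound 3 `O=C(/C=C\Nc1ccc(O)cc1)c1cn(-c2ccccc2)nc1-c1ccc(Cl)cc1` differs from compound 1 in the core by chloro in place of hydrogen on an aromatic carbon; in this assay compound 3 gives 1910 nM, a step of a 1.7-fold lower number from compound 1 to compound 3 (0.23 log units; within the scatter). All three measured numbers thus lie within the scatter of one another, and no ordering among them is claimed.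

Compound 4 `COc1ccc(N/C=C\C(=O)c2cn(-c3ccccc3)nc2-c2ccc(Cl)cc2)cc1` is not yet measured. Among the measured compounds shown here, it differs from compound 3 by methyl in place of hydrogen on an oxygen on an aromatic ring, the same change as the one measured between compound 1 and compound 2, at the same place, here set on the core of compound 3. That single earlier example of the change gave a 1.0-fold higher number from compound 1 to compound 2 (0.01 log units; within the scatter). The step expected in this assay is estimated as a 1.0-fold higher number from compound 3 to compound 4 (0.01 log units; within the scatter), resting on that earlier step and on compound 2 with its value of 3250 nM sitting close to compound 3. Compound 4 is therefore expected to give about 1950 nM in this assay, estimated between 950 nM and 4000 nM.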

Compound 4, half-maximal inhibitory concentration: 6460 nM
For compound 4 the middle estimate is 3.3-fold (0.52 log units) below the measured one, outside the stated range (above it).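

On the chloro core, hydroxy to methoxy gives a 3.4-fold higher number from compound 3 to compound 4 (0.53 log units; beyond the scatter) in this assay, so the change does not carry over unchanged from the core of compound 1: the same change on two cores in this assay, a 1.0-fold higher number (0.01 log units; within the scatter) from compound 1 to compound 2 and a 3.4-fold higher number (0.53 log units; beyond the scatter) from compound 3 to compound 4, 3.3-fold (0.52 log units) apart, beyond the scatter of two such steps

Read the other way round, chloro in place of hydrogen on an aromatic carbon gives a 2.0-fold higher number from compound 2 to compound 4 (0.30 log units; within the scatter) on the methoxy side, and this step also differs from its counterpart on the hydroxy side: the same change on two cores in this assay, a 1.7-fold lower number (0.23 log units; within the scatter) from compound 1 to compound 3 and a 2.0-fold higher number (0.30 log units; within the scatter) from compound 2 to compound 4, 3.3-fold (0.52 log units) apart, beyond the scatter of two such steps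

Both comparisons rest on the same four compounds and form a single case, so they show that the two changes do not combine additively here, but they establish no general rule for the series and do not explain the difference.

Going by these compounds, it remains open whether the shift seen with hydroxy to methoxy is tied to chloro or would also appear with a bromo or methyl group in its place. Also open, on these data alone, is whether an ethoxy group or an amine in place of the methoxy would read closer to compound 3 or to compound 4.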